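Thiocarbamate series: aryl swap on the amide-type nitrogen

The source may report more compounds than this note shows. Statements on the series, on what has been measured and on what is new or still open speak of the compounds shown alone.

Three compounds have numbers in an ADME assay for pharmacokinetics, in phosphate buffer, with a stated time of 0.25 h, tested at 60 uM, at a dose of 60 microM; on this read-out higher numbers stand for higher exposure at the dose given and lower numbers for lower exposure. Compound 1 `Cc1ccc(NC(=S)OCCNC(=O)C(C)(C)Oc2ccc(Cl)cc2)cc1` gives 15800 nM. Compound 3 `CC(C)(Oc1ccc(Cl)cc1)C(=O)Oc1ccc(C(N)=S)cc1` gives 17300 nM, and compound 2 `O=C(Oc1ccc(-c2cc(=S)ss2)cc1)c1cccnc1` gives 12000 nM. Compound 1 sits alongside both, its gaps to compound 3 and to compound 2 each within the usual scatter, so the three values cannot be ordered on this evidence.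

Compound 4 `CC(C)(Oc1ccc(Cl)cc1)C(=O)NCCOC(=S)Nc1ccc([N+](=O)[O-])cc1Cl` has not been measured. It differs from compound 1 in one place (2-chloro-4-nitrophenyl in place of 4-methylphenyl on an amide-type nitrogen). Among the measured compounds shown here, no measured pair in the set shows the effect of such a change, so nothing here points to a step beyond the scatter in either direction. The expected step of a 1.2-fold lower number from compound 1 to compound 4 (0.08 log units; within the scatter) is therefore small. Compound 4 is estimated at 13000 nM, with a range of 6000 nM to 28000 nM.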

Compound 4, maximal plasma concentration: 17200 nM
Estimate against measurement, compound 4: 1.3-fold (0.12 log units) below, within the range that was stated.
By their numbers in this assay, from the lowest: compounds 2, 1, 4 and 3 (each within the scatter of the next).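

Among the compounds shown here, on the amide-type nitrogen, 2-chloro-4-nitrophenyl in place of 4-methylphenyl gives the first direct reading at this position: in this assay the change gives a 1.1-fold higher number from compound 1 to compound 4 (0.04 log units; within the scatter). The entering group has more heavy atoms and brings hydrogen-bond acceptors, yet the read-out does not separate the two compounds. Nothing available gives a reason for this result. Still open, going by these compounds, is whether an aryl ring carrying an amine or a carboxylic acid, or a longer alkyl chain on this nitrogen, would stay within the scatter. On these data alone, the effect of a carbonyl in place of the thiocarbonyl is also open.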